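Compound 4: 1,3-thiazol-2-yl in place of 5-fluoropyrimidin-2-yl

The source may hold more compounds than are shown below. What is called first, only, known or untested is meant among the compounds shown, and "the series" means these compounds.

In a toxicity assay on HepG2 2.2.15 cells (Homo sapiens) for cytotoxicity, read by CellTiter-Glo (on this read-out lower numbers stand for higher toxicity in this test and higher numbers for lower toxicity in this test), compound 1 (`O=C(Nc1cc(F)c(F)c(F)c1)N1Cc2c(-c3ccc(F)cc3F)cnn2CC1C1CC1`) gives 32100 nM and compound 2 (`O=C1NC(c2ccccc2)CN1c1cnn2c1CN(C(=O)Nc1cc(F)c(F)c(F)c1)C(C1CC1)C2`) gives 38500 nM on the same read-out. Among the measured compounds shown here, these two are joined by a 1.2-fold higher number from compound 1 to compound 2 (0.08 log units; within the scatter) and that is the only measured step in the set. Compound 3 (`O=C1CC(c2ncc(F)cn2)CN1c1cnn2c1CN(C(=O)Nc1cc(F)c(F)c(F)c1)C(C1CC1)C2`) reaches 115000 nM as the highest of the three numbers, and its gap to each of the other two lies beyond the scatter.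

Compound 4 (`O=C1CC(c2nccs2)CN1c1cnn2c1CN(C(=O)Nc1cc(F)c(F)c(F)c1)C(C1CC1)C2`) differs from compound 3 in one place (1,3-thiazol-2-yl in place of 5-fluoropyrimidin-2-yl on a saturated ring carbon) with 1,3-thiazol-2-yl in place of 5-fluoropyrimidin-2-yl on a saturated ring carbon. For the measured compounds named here, no measured step tests a change at that carbon. The step from compound 1 to compound 2 concerns a different place, so it gives only weak guidance, and its size stays within the scatter. Compound 2 at 38500 nM does show that the number in this set need not stay as high as in compound 3 at 115000 nM when the group changes. No step beyond the scatter is therefore expected in this assay and any lean is expected to be towards a lower number. The estimated change is a 1.4-fold lower number from compound 3 to compound 4 (0.16 log units; within the scatter) on present evidence. For compound 4 the estimated value is 80000 nM with an expected range from 30000 nM to 160000 nM until a measurement is available.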

Compound 4, half-maximal cytotoxic concentration: 115000 nM
For compound 4 the middle estimate is 1.4-fold (0.16 log units) below the measured one; measured number inside the range.
By their numbers in this assay, from the lowest: compounds 1 and 2 (each within the scatter of the next); then compounds 3 and 4 (each within the scatter of the next).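

In this assay, the first read at the saturated ring carbon of the five-membered non-aromatic ring gives no change at the digits printed from compound 3 to compound 4 (within the scatter), so 1,3-thiazol-2-yl and 5-fluoropyrimidin-2-yl are not told apart at this position, even though the rings differ in size and hetero atoms and only the leaving group carries fluorine. With the thiazole in place, the whole 2-oxo-4-(1,3-thiazol-2-yl)pyrrolidin-1-yl group on the aromatic carbon gives a 3.0-fold higher number from compound 2 to compound 4 (0.48 log units; beyond the scatter) against the 2-oxo-4-phenylimidazolidin-1-yl group and a 3.6-fold higher number from compound 1 to compound 4 (0.55 log units; beyond the scatter) against 2,4-difluorophenyl, both modest steps that set compound 4 apart from compounds 1 and 2 in this assay. Nothing measured alongside these numbers speaks to what lies behind them.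

Going by these compounds, both groups tested at the saturated ring carbon are aromatic rings, so it remains open whether an amine or a carboxylic acid there would leave the number in this assay unchanged. Also open, on these data alone, is whether a longer alkyl chain at that carbon would stay within the scatter of compound 4 or would bring a step of the size seen from compound 2 to compound 4.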